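Halogen swap on the aryl thiosemicarbazone: chloro to bromo

A few compounds are considered here, and "the series" means these few. Any claim that something is new, unique, unknown or untested is made for them only; others in the source may bear on it.

Compounds measured in a functional assay on U-251 cells (Homo sapiens) for inhibition, read by sulforhodamine B assay, with a stated time of 48 h; on this read-out higher numbers stand for weaker inhibition of growth and lower numbers for stronger inhibition of growth:
compound 1 `CCc1ccc(NC(=S)N/N=C/c2cccs2)cc1` – > 100000 nM.
compound 2 `Cc1ccc(NC(=S)N/N=C/c2cccs2)cc1` – 12600 nM.
compound 3 `S=C(N/N=C/c1cccs1)Nc1ccc(Cl)cc1` – 8300 nM.

The value of compound 1 is a limit of this assay, not a number (the limit of > 100000 nM in this assay, at which 1 of the 3 values shown sits). Compound 3 stands lowest of the two numbers given, with compound 2 nearest; the step of a 1.5-fold lower number from compound 2 to compound 3 (0.18 log units; within the scatter) lies within the scatter, whereas an at least 12-fold lower number from compound 1 to compound 3 (1.08 log units; beyond the scatter) and an at least 7.9-fold lower number from compound 1 to compound 2 (0.89 log units; beyond the scatter) are beyond it. Compound 4 `S=C(N/N=C/c1cccs1)Nc1ccc(Br)cc1` differs from compound 3 only by bromo in place of chloro on an aromatic carbon. The step from methyl to chloro on this aromatic carbon changed little; a second halogen at the same place is therefore expected to give a step of a 1.2-fold lower number from compound 3 to compound 4 (0.07 log units; within the scatter) that stays within the scatter. Compound 4 is estimated at 7000 nM, between 3000 nM and 20000 nM.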

Compound 4, concentration for 50% growth inhibition: 4200 nM
The estimate for compound 4 lay 1.7-fold (0.22 log units) above the measured number, and the stated range covers the measured number.
By their numbers in this assay, from the lowest: compounds 4, 3 and 2 (each within the scatter of the next, the first and the last beyond it). At a limit, above all of these: compound 1.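

In this assay, swapping chloro for bromo on this aromatic carbon gives a 2.0-fold lower number from compound 3 to compound 4 (0.30 log units; within the scatter) and so leaves the two halogens unseparated. Bromo, unlike chloro, does part from methyl, with a 3.0-fold lower number from compound 2 to compound 4 (0.48 log units; beyond the scatter) beyond the scatter, and the gap to ethyl grows to an at least 23-fold lower number from compound 1 to compound 4 (1.37 log units; beyond the scatter) on the same carbon. The value of compound 1 is a limit and not a number: the limit of > 100000 nM in this assay, at which 1 of the 4 values shown sits.

On these data alone, whether iodo, methoxy or an amine at this place would extend the series stays open, as does whether a propyl chain would behave like ethyl.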